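Chloro for methoxy, repeated on a second core

The compounds below may be only part of what the source reports. "The series", "measured", "known", "first", "only" and "open" are said of these compounds alone.

In an assay on HeLa cells for displacement of a labelled ligand from 5-hydroxytryptamine receptor 6 (Homo sapiens) (on this read-out higher numbers stand for weaker inhibition and lower numbers for stronger inhibition), the measured compounds stand as follows:

compound 1, `O=S(=O)(c1ccc(Cl)cc1)c1n[nH]c2cccc(N3CCNCC3)c12`, gives 125 nM
compound 2, `COc1ccc(S(=O)(=O)c2n[nH]c3ccc(N4CCN(C)CC4)cc23)cc1`, gives 12 nM
compound 3, `COc1ccc(S(=O)(=O)c2n[nH]c3cccc(N4CCNCC4)c23)cc1`, gives 88 nM

Compound 3 and compound 1 share one core and differ in a single place: chloro in place of methoxy on an aromatic carbon. The step this change made is a 1.4-fold higher number from compound 3 to compound 1 (0.15 log units; within the scatter), so within this pair the two groups cannot be told apart on this read-out.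

Compound 2 has the lowest number of the three. Its core is not that of compound 3; how the two cores differ is not broken down here, and the gap between compound 3 and compound 2 is beyond the scatter, as is the gap between compound 1 and compound 2.

Compound 4, `CN1CCN(c2ccc3[nH]nc(S(=O)(=O)c4ccc(Cl)cc4)c3c2)CC1`, has not been measured. It differs from compound 2 by chloro in place of methoxy on an aromatic carbon. The place is described in the same words as for the change from compound 3 to compound 1, so this is the same change carried onto the core of compound 2.

Within the data shown here, the expectation for compound 4 rests on the one measured instance: because the change gave a 1.4-fold higher number from compound 3 to compound 1 (0.15 log units; within the scatter), a step of similar size, a 1.4-fold higher number from compound 2 to compound 4 (0.15 log units; within the scatter), is expected from compound 2 to compound 4. Compound 4 is therefore estimated at 17 nM in this assay, with a likely range from 7 nM to 45 nM; the width allows for the change behaving somewhat differently on a different core.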

Compound 4, inhibition constant: 8.1 nM
Beside the measured number, compound 4's estimate is 2.1-fold (0.32 log units) above it, and the stated range covers the measured number.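

In this assay, chloro in place of methoxy on the core of compound 2 gives a 1.5-fold lower number from compound 2 to compound 4 (0.17 log units; within the scatter), so on this core, as on the core of compound 3, the two groups cannot be told apart. Set side by side, the two steps point in opposite directions, but that difference carries no weight: the same change on two cores in this assay, a 1.4-fold higher number (0.15 log units; within the scatter) from compound 3 to compound 1 and a 1.5-fold lower number (0.17 log units; within the scatter) from compound 2 to compound 4, 2.1-fold (0.32 log units) apart, within the scatter of two such steps. Among these compounds, this shows that, on these two cores, the change from 4-methoxyphenyl to 4-chlorophenyl leaves the number unchanged within the scatter and that the result carried over from one core to the other; it does not show that the two groups are interchangeable across the series, as it rests on only two pairs and gives no reason for the result.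

The compounds shown leave open whether a different group at this place on the aromatic ring, such as an amine, a carboxylic acid or a longer chain, would move the number beyond the scatter. Also open, from the compounds shown here alone, is whether the exchange of chloro for methoxy would stay within the scatter on a third core or on a read-out other than this binding measurement.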